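This account rests on a few compounds, and the source may have more. Where it says the series, first, only, none or still open, it means among the compounds named here.

In an ADME assay on Vero cells (Chlorocebus sabaeus) for cytotoxicity, read by crystal violet staining (on this read-out lower numbers stand for higher toxicity in this test and higher numbers for lower toxicity in this test), compound 1 (`Fc1ccc(F)c(/N=N/Nc2ccccc2)c1`) gives 80000 nM and compound 2 (`Cc1c(/N=N/c2cccc(C(F)(F)F)c2)ccc(NC[C@@H]2CCCN3CCCC[C@H]23)c1C`) gives 80000 nM, so compound 2 stands level with compound 1. Compound 3 (`Cc1c(/N=N/c2ccccc2)ccc(NC[C@@H]2CCCN3CCCC[C@H]23)c1C`) differs from compound 2 by one change, hydrogen in place of trifluoromethyl on an aromatic carbon. Going by the values given here, no measured pair shows this change, so the expectation rests on the structures alone, and no step beyond the scatter is expected in this assay. The expected step is a 1.1-fold lower number from compound 2 to compound 3 (0.06 log units; within the scatter). The estimated value for compound 3 is 70000 nM, with a range of 30000 nM to 130000 nM.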

Compound 3, half-maximal cytotoxic concentration: 60000 nM
Compound 3: middle estimate off by 1.2-fold (0.07 log units), on the high side; measured number inside the range.
By their numbers in this assay, from the lowest: compounds 3, 1 and 2 (each within the scatter of the next).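

Putting hydrogen in place of trifluoromethyl on this aromatic carbon gives a 1.3-fold lower number from compound 2 to compound 3 (0.12 log units; within the scatter) in this assay. The two compounds therefore cannot be told apart in this test, so for this pair the trifluoromethyl group makes no difference beyond ordinary repeat scatter. Nothing measured here offers an explanation for this result.

Only hydrogen and trifluoromethyl are shown at this place, so the result says little about groups of other kinds. An amine, a carboxylic acid or a longer chain on the same carbon could still shift the number.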